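This account rests on a few compounds, and the source may have more. Where it says the series, first, only, none or still open, it means among the compounds named here.

Within the data shown here, compound 2 `CNC(=O)c1ccc(Oc2cccc(NC(=S)Nc3ccc(Br)c(C(F)(F)F)c3)c2)nc1` carries the only number among the three values seen in a functional assay on PC-3 cells (Homo sapiens) for antiproliferative activity, read by MTT assay (a higher number here means a weaker inhibitor, a lower number a stronger inhibitor), where compound 2 gives 2670 nM. Compound 1 `CNC(=O)c1ccc(Oc2cccc(NC(=S)Nc3ccc(C)cc3)c2)nc1` reaches only a limit: in this assay compound 1 gives > 100000 nM. Compound 3 `CNC(=O)c1ccc(Oc2cccc(NC(=S)Nc3ccc(OC)cc3)c2)nc1` likewise stops at a limit, compound 3 giving > 100000 nM. The step from compound 1 to compound 3 is a step that the two limits leave unreadable from compound 1 to compound 3 because the limit of > 100000 nM in this assay, at which 2 of the 3 values shown sit, hides its size. Compound 4 `CNC(=O)c1ccc(Oc2cccc(NC(=S)Nc3ccc(Cl)c(C(F)(F)F)c3)c2)nc1` differs from compound 2 by chloro in place of bromo on an aromatic carbon. Among the measured compounds shown here, no measured step bears on this change; compound 1 and compound 2 differ in more than one place, so their pair offers no reading of it. For compound 4 the expected step of a 1.3-fold higher number from compound 2 to compound 4 (0.12 log units; within the scatter) is within the scatter. Compound 4 is therefore estimated at 3500 nM, between 1200 nM and 10000 nM.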

Compound 4, half-maximal inhibitory concentration: 1980 nM
Estimate against measurement, compound 4: 1.8-fold (0.25 log units) above; measured number inside the range.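

The carbon ortho to a trifluoromethyl group now has its first readable step, a 1.3-fold lower number from compound 2 to compound 4 (0.13 log units; within the scatter) in this assay, so chloro and bromo are not told apart at this carbon. Compound 1 and compound 3 stop at limits, and the step between them cannot be read. No measurement shown gives a reason for the step at this carbon. Still open, from the compounds shown here alone, is how an amine or a carboxylic acid would read at this carbon. Also open, going by these compounds, is how chloro or bromo would read without the trifluoromethyl group.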